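Hydroxamate sulfone series: ketone to anilide linker step

The compounds below may be only part of what the source reports. "The series", "measured", "known", "first", "only" and "open" are said of these compounds alone.

Measured so far:
compound 1 `O=C(NCCCOc1ccc(S(=O)(=O)C2(C(=O)NO)CCOCC2)cc1)c1ccc(OC(F)(F)F)cc1` gives 2200 nM
compound 2 `CCCC(C)(C)C(=O)NCCCOc1ccc(S(=O)(=O)C2(C(=O)NO)CCOCC2)cc1` has no result reported, its entry reading "not determined" (no result reported)
compound 3 `CN(C)c1ccc(C(=O)CCCOc2ccc(S(=O)(=O)C3(C(=O)NO)CCOCC3)cc2)cc1` gives 930 nM

In an assay on isolated protein for inhibition of matrix metalloproteinase-9 (Homo sapiens) (on this read-out lower numbers stand for stronger inhibition and higher numbers for weaker inhibition), compound 3 stands at the lowest of the two numbers; compound 1 sits at a higher number, beyond the scatter. Compound 2 contributes no value.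

Compound 4 `CN(C)c1ccc(NC(=O)CCCOc2ccc(S(=O)(=O)C3(C(=O)NO)CCOCC3)cc2)cc1` differs from compound 3 by (4-(dimethylamino)phenyl)amino in place of 4-(dimethylamino)phenyl on a carbonyl carbon. Within the data shown here, no pair of measured compounds differs in this single place, so no measured step sets the size of the change. Compound 4 is expected to land close to compound 3, with the step of a 1.0-fold lower number from compound 3 to compound 4 (0.01 log units; within the scatter) not reaching beyond the scatter in this assay. Compound 4 is thus estimated at 900 nM, with a range from 300 nM to 3000 nM.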

Compound 4, half-maximal inhibitory concentration: 960 nM
Estimate against measurement, compound 4: 1.1-fold (0.03 log units) below, and the stated range covers the measured number.
By their numbers in this assay, from the lowest: compounds 3 and 4 (each within the scatter of the next); then compound 1.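

This place now has a measured step: in this assay, (4-(dimethylamino)phenyl)amino in place of 4-(dimethylamino)phenyl on a carbonyl carbon gives a 1.0-fold higher number from compound 3 to compound 4 (0.01 log units; within the scatter). The extra nitrogen and the amide hydrogen it carries therefore leave the read-out within the scatter, so the ketone and the anilide read alike here. No measured property of either compound bears on this result.

Open, from the compounds shown here alone, is whether the two linkers still read alike with a carboxylic acid in place of the dimethylamino group. Going by these compounds, a longer chain on the carbonyl carbon also remains open.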